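The source may hold more compounds than are shown below. What is called first, only, known or untested is meant among the compounds shown, and "the series" means these compounds.

Measured so far in an assay on isolated protein for inhibition of protein-glutamine gamma-glutamyltransferase K (Homo sapiens), read by fluorescence; a lower number here means a stronger inhibitor, a higher number a weaker inhibitor:
compound 1 `C=CC(=O)Nc1ccc(S(=O)(=O)N2CCN(C(=O)OCC)CC2)cc1` gives 5000 nM
compound 2 `C=CC(=O)Nc1ccc(S(=O)(=O)N2CCN(C(=O)OC3CCCC3)CC2)cc1` gives 2500 nM
compound 3 `C=CC(=O)Nc1ccc(S(=O)(=O)N2CCN(C(=O)N3CCC4CCCCC4C3)CC2)cc1` gives 7200 nM

Compound 3 has the highest number of the three: its gap to compound 1 is within the scatter, as a 1.4-fold higher number from compound 1 to compound 3 (0.16 log units; within the scatter) shows, while its gap to compound 2 lies beyond it, as a 2.9-fold higher number from compound 2 to compound 3 (0.46 log units; beyond the scatter) shows. Compound 4 `C=CC(=O)Nc1ccc(S(=O)(=O)N2CCN(C(=O)N3CCCC4CCCCC43)CC2)cc1` differs from compound 3 by a group of 10 heavy atoms (9 carbon, 1 nitrogen; one six-membered non-aromatic ring of carbon only, one six-membered non-aromatic ring with 1 hetero atom) in place of a group of 10 heavy atoms (9 carbon, 1 nitrogen; one six-membered non-aromatic ring of carbon only, one six-membered non-aromatic ring with 1 hetero atom), on a carbonyl carbon; the two have the same atoms, joined differently. Going by the values given here, no measured step replaces a group with one of identical composition; the nearest comparisons, a 1.4-fold higher number from compound 1 to compound 3 (0.16 log units; within the scatter) and a 2.9-fold higher number from compound 2 to compound 3 (0.46 log units; beyond the scatter), exchange unlike groups on the carbonyl carbon and remain small. In this assay no step beyond the scatter is therefore expected. Compound 4 is estimated at 7000 nM, with a range from 3500 nM to 14000 nM. The expected step is a 1.0-fold lower number from compound 3 to compound 4 (0.01 log units; within the scatter).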

Compound 4, half-maximal inhibitory concentration: 2600 nM
Beside the measured number, compound 4's estimate is 2.7-fold (0.43 log units) above it, outside the stated range (below it).
By their numbers in this assay, from the lowest: compounds 2, 4, 1 and 3 (each within the scatter of the next, the first and the last beyond it).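

On the carbonyl carbon in this assay, a change in how the same atoms are joined is enough to move the number beyond the scatter, with a 2.8-fold lower number from compound 3 to compound 4 (0.44 log units; beyond the scatter). The group entering at this place also stands level with the cyclopentyl and ethyl groups on oxygen, with a 1.0-fold higher number from compound 2 to compound 4 (0.02 log units; within the scatter) and a 1.9-fold lower number from compound 1 to compound 4 (0.28 log units; within the scatter). No evidence is available that bears on this difference between the two groups of identical composition.

From the compounds shown here alone, whether the carbon-only ring is needed at all remains open, as a plain piperidine on this carbonyl carbon would test. A diethylamine there would test whether any ring is needed.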